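The compounds below may be only part of what the source reports. "The series", "measured", "known", "first", "only" and "open" are said of these compounds alone.

Values measured so far in a functional assay on DU-145 cells (Homo sapiens) for inhibition, read by trypan blue exclusion, with a stated time of 96 h (a lower number here means a stronger inhibitor of growth, a higher number a weaker inhibitor of growth), are:
compound 1 `O=C(/C(=C\c1ccc([N+](=O)[O-])c(O)c1)SCc1ccc(Br)cc1)c1ccc([N+](=O)[O-])cc1` gives 1000 nM
compound 2 `Cc1ccc(CS(=O)(=O)/C(=C/c2ccc(N(C)C)cc2)C(=O)c2ccc(Cl)cc2)cc1` gives 50000 nM
compound 3 `O=C(/C(=C\c1ccc(O)c([N+](=O)[O-])c1)SCc1ccc(Br)cc1)c1ccc([N+](=O)[O-])cc1` gives 10000 nM

Compound 1 has the lowest number of the three, with compound 3 (10000 nM) nearest and compound 2 (50000 nM) furthest. Compound 4 `O=C(/C(=C\c1ccc([N+](=O)[O-])c(O)c1)SCc1ccc(Br)cc1)C1CCNC1` has not yet been measured. It carries pyrrolidin-3-yl in place of 4-nitrophenyl on a carbonyl carbon and is otherwise the same as compound 1. Within the data shown here, the only measured step is a 10-fold higher number from compound 1 to compound 3 (1.00 log units; beyond the scatter) and it lies at another place, not on a carbonyl carbon. No measurement therefore tests the new change directly, though that step shows that one change in this small set can move the number beyond the scatter. Among the measured compounds shown here, since compound 1 (1000 nM) has the lowest number so far, a move in this assay toward a higher number, of similar size to that step, is expected. The estimated outcome is a 6.0-fold higher number from compound 1 to compound 4 (0.78 log units; beyond the scatter) with wide uncertainty. For compound 4 the estimated value is 6000 nM with an expected range from 1000 nM to 40000 nM in this measurement.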

Compound 4, concentration for 50% growth inhibition: > 100000 nM
Compound 4: a limit, no number; the forecaster's own chance of this, stated with the estimate: 10%; middle value at least 16-fold (1.22 log units) from the limit.
By their numbers in this assay, from the lowest: compound 1; then compound 3; then compound 2. At a limit, above all of these: compound 4.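

The carbonyl carbon now proves to be a sensitive place in the molecule: in this assay, pyrrolidin-3-yl in place of 4-nitrophenyl gives an at least 100-fold higher number from compound 1 to compound 4 (2.00 log units; beyond the scatter), a larger step than the only earlier one, a 10-fold higher number from compound 1 to compound 3 (1.00 log units; beyond the scatter). For compound 4, > 100000 nM is a limit of the assay and not a number. Within this set, the growth inhibition seen with 4-nitrophenyl on this carbon does not survive the exchange for pyrrolidin-3-yl, and only compound 4 stands at this limit: the limit of > 100000 nM in this assay, at which 1 of the 4 values shown sits.

On these data alone, the exchange alters several things at once, including ring size, aromatic character and the ring nitrogen, so which of these matters remains open. A plain phenyl or a cyclopentyl ring on the same carbonyl carbon would help to separate them.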